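Enantiomer of the free-acid lactone in the series

A few compounds are considered here, and "the series" means these few. Any claim that something is new, unique, unknown or untested is made for them only; others in the source may bear on it.

Measured compounds:
compound 1, `CC1(C)[C@H]2CC3=N[C@H](CCC(=O)O)C(=O)O[C@]3(C)[C@@H]1C2`: > 1200000 nM
compound 2, `CC1(C)[C@H]2CC3=NCC(=O)O[C@]3(C)[C@@H]1C2`: > 2000000 nM
compound 3, `CC(C)(C)OC(=O)CC[C@H]1N=C2C[C@H]3C[C@H](C3(C)C)[C@@]2(C)OC1=O`: > 1200000 nM

Among the compounds with values here, every number so far is a limit of the assay, not a measured value. In an ADME assay on MCF-10A cells (Homo sapiens) for antiproliferative activity, read by sulforhodamine B assay, with a stated time of 48 h (a lower number here means a stronger inhibitor, a higher number a weaker inhibitor), compound 1 gives only the limit > 1200000 nM. Compound 2 likewise stops at the limit > 2000000 nM in this assay. Compound 3 also stops at a limit, > 1200000 nM in this assay. Two of the three values sit at the limit of > 1200000 nM in this assay, at which 2 of the 3 values shown sit, and the remaining one at the limit of > 2000000 nM in this assay, at which 1 of the 3 values shown sits, so compound 1 stands nowhere within the measured range; it is simply inactive up to its limit.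

The two steps that start from compound 1 are a step that the two limits leave unreadable from compound 1 to compound 2 and a step that the two limits leave unreadable from compound 1 to compound 3: neither can be read in size or direction, so they give no scale for any change on this core.

Compound 4, `CC1(C)[C@@H]2CC3=N[C@@H](CCC(=O)O)C(=O)O[C@@]3(C)[C@H]1C2`, differs from compound 1 as follows: the two compounds have the same atoms and bonds and differ only in configuration as drawn: 4 of 4 stereo elements differ (all stereocentres are inverted: mirror images); a stereocentre at a saturated ring carbon is drawn R in compound 1 and S in compound 4; a stereocentre at a saturated ring carbon is drawn R in compound 1 and S in compound 4; a stereocentre at a saturated ring carbon is drawn R in compound 1 and S in compound 4; a stereocentre at a saturated ring carbon is drawn R in compound 1 and S in compound 4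

Within the data shown here, no measured step touches a change in configuration, and the bracketing limits allow nothing to be placed against it. The expectation is therefore a step of no readable size, a step that the limit leaves unreadable from compound 1 to compound 4, with compound 4 most likely returning another limit. Compound 4 is estimated at 1500000 nM in this assay, within 700000 nM to 3000000 nM.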

Compound 4, half-maximal inhibitory concentration: > 1200000 nM
Compound 4: a limit, no number; the forecaster's own chance of this, stated with the estimate: 85%; the middle value lies beyond the limit too.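

In this assay compound 4 gives > 1200000 nM, a limit of the assay and not a number. Compound 1 also stands at a limit, so the step between compound 1 and compound 4 cannot be read in size or direction. The compounds shown leave open whether inverting all stereocentres changes activity on the shared core at any concentration that yields a measured number.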